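Hydrogen for methoxy on compound 3

This account rests on a few compounds, and the source may have more. Where it says the series, first, only, none or still open, it means among the compounds named here.

In an ADME assay on THLE-2 cells (Homo sapiens) for cytotoxicity, read by MTT assay (on this read-out lower numbers stand for higher toxicity in this test and higher numbers for lower toxicity in this test), compound 3 (`COc1ccc(-c2nc3c(c(-c4ccccc4)nn3-c3ccccc3)c(-c3ccc(N4CCN(C)CC4)cc3)c2C#N)cc1`) gives 37500 nM. That value lies within the scatter of both compound 1 (`COc1ccc(C(=O)C=CNc2cc(-c3ccccc3)nn2-c2ccccc2)cc1`) at 35200 nM and compound 2 (`O=C(C=CNc1cc(-c2ccccc2)nn1-c1ccccc1)c1ccccc1`) at 53400 nM. Compound 4 (`CN1CCN(c2ccc(-c3c(C#N)c(-c4ccccc4)nc4c3c(-c3ccccc3)nn4-c3ccccc3)cc2)CC1`) carries hydrogen in place of methoxy on an aromatic carbon, 4-methoxyphenyl to phenyl (hydrogen in place of methoxy on an aromatic carbon). Among the measured compounds shown here, one measured step bears on this change, on a different core: a 1.5-fold higher number from compound 1 to compound 2 (0.18 log units; within the scatter). With that single precedent inside the scatter, no shift beyond the scatter is expected in this assay. The expected step is a 1.2-fold higher number from compound 3 to compound 4 (0.08 log units; within the scatter), which would also stay within the scatter. For compound 4 the estimated value is 45000 nM, with an expected range from 22000 nM to 85000 nM.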

Compound 4, half-maximal cytotoxic concentration: 15100 nM
Compound 4: middle estimate off by 3.0-fold (0.47 log units), on the high side; the measured number lies below the stated range.
By their numbers in this assay, from the lowest: compound 4; then compounds 1, 3 and 2 (each within the scatter of the next).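

In this assay, among the compounds shown here, hydrogen in place of methoxy on an aromatic carbon gives a 2.5-fold lower number from compound 3 to compound 4 (0.40 log units; beyond the scatter), the only step of this change that lies beyond the scatter. The outcome of this change at this position therefore depends on the core that carries it: the same change on two cores in this assay, a 1.5-fold higher number (0.18 log units; within the scatter) from compound 1 to compound 2 and a 2.5-fold lower number (0.40 log units; beyond the scatter) from compound 3 to compound 4, 3.8-fold (0.58 log units) apart, beyond the scatter of two such steps

The compounds shown leave open whether the lower number is specific to losing methoxy or would also appear with another group in this place, such as a hydroxyl, a fluorine or an ethoxy group. They also leave open how the change would read on further cores.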